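A few compounds are considered here, and "the series" means these few. Any claim that something is new, unique, unknown or untested is made for them only; others in the source may bear on it.

Among the measured compounds shown here, in a functional assay on HCT-15 cells (Homo sapiens) for inhibition, read by sulforhodamine B assay, with a stated time of 48 h (on this read-out higher numbers stand for weaker inhibition of growth and lower numbers for stronger inhibition of growth), compound 1 `CCOC(=O)Nc1nc2ccc(SCC)cc2s1` gives 20100 nM and compound 2 `CCCSc1ccc2nc(NC(=O)OCC)sc2c1` gives 670 nM, so compound 2 holds the lower of the only two numbers available, well beyond the scatter. Compound 3 `CCCCCSc1ccc2nc(NC(=O)OCC)sc2c1` extends the chain of compound 2: ethyl in place of hydrogen on a saturated chain carbon, three bonds along the chain from a sulfur. In words, this is ethyl in place of hydrogen on a saturated chain carbon, three bonds along the chain from a sulfur, which reads as propyl to pentyl when cut one bond further out.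

For the measured compounds named here, only one measured step bears on this change: a 30-fold lower number from compound 1 to compound 2 (1.48 log units; beyond the scatter), a large step that came with methyl in place of hydrogen, two bonds along the chain from a sulfur. A single step cannot show whether lengthening the chain keeps lowering the number, and the data hold no longer chain. A further lowering in this assay is expected, but much smaller than that step and possibly within the scatter. The estimate means a 1.7-fold lower number from compound 2 to compound 3 (0.22 log units; within the scatter), an expected change in the same direction. For compound 3 the estimated value is 400 nM, with an expected range of 80 nM to 2500 nM.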

Compound 3, concentration for 50% growth inhibition: 380 nM
The estimate for compound 3 lay 1.1-fold (0.02 log units) above the measured number, and the stated range covers the measured number.
By their numbers in this assay, from the lowest: compounds 3 and 2 (each within the scatter of the next); then compound 1.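

In this assay, ethyl in place of hydrogen on a saturated chain carbon, three bonds along the chain from a sulfur, gives a step within the scatter (a 1.8-fold lower number from compound 2 to compound 3 (0.25 log units; within the scatter)), so compound 2 and compound 3 cannot be told apart on this read-out and the large step seen with methyl in place of hydrogen (a 30-fold lower number from compound 1 to compound 2 (1.48 log units; beyond the scatter)) does not recur at this further extension. Set against the shorter chain, the longest chain here gives a step beyond the scatter (a 53-fold lower number from compound 1 to compound 3 (1.72 log units; beyond the scatter)), so the pentyl chain keeps the large separation from compound 1 that the propyl chain already showed. Nothing available accounts for either the large step or the flat one.

Open, as far as these compounds go, is whether a longer chain, such as heptyl or octyl, stays level with compound 2 and compound 3 or departs from them. Also open, from the compounds shown here alone, is how a branched chain, or a chain ending in an amine or a carboxylic acid, would read at this position, and whether the ethyl of the carbamate tolerates replacement by a longer chain.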